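The source may hold more compounds than are shown below. What is called first, only, known or untested is meant among the compounds shown, and "the series" means these compounds.

In a functional assay for inhibition, with Rattus norvegicus as the target (on this read-out lower numbers stand for stronger inhibition and higher numbers for weaker inhibition), three compounds sharing one core have been measured. Compound 1 `CC(/N=c1\c(O)c(O)\c1=N/c1cccnc1O)C(C)(C)C` gives > 30000 nM, which is a limit of the assay and not a number. Among the measured compounds shown here, compound 2 `CC(/N=c1\c(O)c(O)\c1=N/c1cncc(Br)c1)C(C)(C)C` gives 11700 nM, and compound 3 `CC(/N=c1\c(O)c(O)\c1=N/c1ccc(Br)cc1)C(C)(C)C` gives 1260 nM, the lowest number so far.

Compound 4 `CC(=O)c1ccc(/N=c2\c(O)c(O)\c2=N/C(C)C(C)(C)C)cc1` differs from compound 3 at one place: acetyl in place of bromo on an aromatic carbon, para to a large group (acetyl in place of bromo on an aromatic carbon).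

The measured steps all exchange the whole aromatic group on the double-bonded nitrogen. The large step is an at least 23-fold lower number from compound 1 to compound 3 (1.37 log units; beyond the scatter), and the modest one is a 9.3-fold lower number from compound 2 to compound 3 (0.97 log units; beyond the scatter). The smallest is an at least 2.5-fold lower number from compound 1 to compound 2 (0.40 log units; beyond the scatter), which rests on a limit. None of them replaces bromo while keeping the 4-substituted phenyl, so they bear on this change only indirectly and show that the number responds strongly to that aromatic group. A single exchange on that phenyl should matter less, so no step beyond the usual scatter is expected, though the direction remains uncertain.

The estimated change is a 1.2-fold higher number from compound 3 to compound 4 (0.08 log units; within the scatter). For compound 4, the expected value is 1500 nM, with an estimated range of 350 nM to 7000 nM.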

Compound 4, half-maximal inhibitory concentration: 21200 nM
Beside the measured number, compound 4's estimate is 14-fold (1.15 log units) below it; the whole stated range lies below it.
By their numbers in this assay, from the lowest: compound 3; then compounds 2 and 4 (each within the scatter of the next). At a limit, above all of these: compound 1.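

In this assay, on an aromatic carbon para to a large group, acetyl in place of bromo gives a 17-fold higher number from compound 3 to compound 4 (1.23 log units; beyond the scatter). The earlier steps shown here all exchanged the whole aromatic group, so they could not show that one substituent on an otherwise unchanged phenyl ring can matter this much. Bromo, with 1 heavy atom, and acetyl, with 3 heavy atoms and a hydrogen-bond acceptor, differ in more than one way, and this single pair cannot tell which difference counts.

Chloro, methyl, methoxy, nitrile or an amine at this same position would help to separate those differences. Any such replacement might also end at a limit of the assay rather than at a number: the limit of > 30000 nM in this assay, at which 1 of the 4 values shown sits.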